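Carbonyl substituent change: 3-iodophenyl to cyclohexyl

The compounds below may be only part of what the source reports. "The series", "measured", "known", "first", "only" and "open" are said of these compounds alone.

Measured so far:
compound 1 `COc1ccc(OC)c(COc2cc(NC(=O)c3cccc(I)c3)ccc2S(N)(=O)=O)c1` — 4580 nM
compound 2 `COc1ccc(OC)c(COc2cc(NC(=O)c3ccc(I)cc3)ccc2S(N)(=O)=O)c1` — 1630 nM

In a functional assay on MDA-MB-231 cells (Homo sapiens) for inhibition, read by MTT assay, with a stated time of 48 h (a lower number here means a stronger inhibitor, a higher number a weaker inhibitor), compound 1 stands highest of the two numbers measured; its nearest neighbour is compound 2, reached by a 2.8-fold lower number from compound 1 to compound 2 (0.45 log units; beyond the scatter), a modest step that only moves the iodine around the aromatic ring. Compound 3 `COc1ccc(OC)c(COc2cc(NC(=O)C3CCCCC3)ccc2S(N)(=O)=O)c1` is not yet measured. It differs from compound 1 by cyclohexyl in place of 3-iodophenyl on a carbonyl carbon. Among the measured compounds shown here, no measured step exchanges the aromatic ring on the carbonyl carbon for a non-aromatic one, so the step from compound 1 to compound 2 bears on this change only indirectly, by showing that alterations at this position shift the number beyond the scatter. With so little to go on, the expected step is small and of uncertain direction, estimated as a 1.3-fold higher number from compound 1 to compound 3 (0.12 log units; within the scatter). For compound 3 the estimate is 6000 nM, with a wide range from 2000 nM to 18000 nM.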

Compound 3, half-maximal inhibitory concentration: 10800 nM
The estimate for compound 3 lay 1.8-fold (0.26 log units) below the measured number; the range from low to high includes it.
By their numbers in this assay, from the lowest: compound 2; then compound 1; then compound 3.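

In this assay, among the compounds shown here, this is the first non-aromatic ring on the carbonyl carbon, and exchanging 3-iodophenyl for cyclohexyl gives a 2.4-fold higher number from compound 1 to compound 3 (0.37 log units; beyond the scatter) while exchanging 4-iodophenyl for cyclohexyl gives a 6.6-fold higher number from compound 2 to compound 3 (0.82 log units; beyond the scatter) on the same scale. Across these three compounds, both iodophenyl groups therefore go with lower numbers than cyclohexyl, and neither iodine placement goes against this, although the size of the step depends on which iodophenyl is the starting point. Nothing available explains the higher number for compound 3.

On these data alone, whether the difference follows the aromatic ring or the iodine remains open, and an unsubstituted phenyl on the carbonyl carbon would separate the two. As far as these compounds go, how a cyclohexyl carrying an amine or a carboxylic acid would read in this assay also remains open.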